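This account rests on a few compounds, and the source may have more. Where it says the series, first, only, none or still open, it means among the compounds named here.

Working notes on the series. Compound 1 `COc1ccc(OC)c(/C=C/c2nnc(Nc3ccc(Cl)cc3)o2)c1` and compound 2 `COc1ccc(OC)c(/C=C/C(=O)N/N=C/c2ccc(Cl)cc2)c1` share a common fragment joined through different linkers to the terminal ring. In a functional assay on KM12 cells (Homo sapiens) for antiproliferative activity, read by sulforhodamine B assay, with a stated time of 48 h (a lower number here means a stronger inhibitor of growth, a higher number a weaker inhibitor of growth), compound 2 gives 8480 nM. Compound 1 reaches only a limit of the assay, > 100000 nM, which is not a number. Compound 2 therefore provides the only numerical reading shown; the other entry is the limit of > 100000 nM in this assay, at which 1 of the 2 values shown sits, belonging to compound 1. Compound 3 `COc1ccc(OC)c(/C=C/C(=O)N/N=C/c2ccccc2)c1` differs from compound 2 by hydrogen in place of chloro on an aromatic carbon. Among the compounds with values here, no step between measured compounds covers this change, so the expectation rests on the single reading for compound 2 alone. A modest weakening of growth inhibition is expected for the step of a 2.1-fold higher number from compound 2 to compound 3 (0.33 log units; beyond the scatter), of a size that may just exceed the usual scatter but stays well short of the limit. Compound 3 is accordingly estimated at 18000 nM in this assay, with a range from 6000 nM to 50000 nM.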

Compound 3, concentration for total growth inhibition: 3750 nM
Compound 3: middle estimate off by 4.8-fold (0.68 log units), on the high side; measured number outside the range, below it.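

In this assay, within the data shown here, the change from 4-chlorophenyl to phenyl gives a 2.3-fold lower number from compound 2 to compound 3 (0.35 log units; beyond the scatter) and is the first reading of any change at this place on the terminal ring. The chloro group is thus not required for growth inhibition in this pair, and the compound with hydrogen at this aromatic carbon is the stronger of the two. No measured property shown bears on this step, so the change in number stands without an explanation.

From the compounds shown here alone, whether the lower number is specific to hydrogen remains open, as does how groups such as fluoro, methoxy or an amine at this place would read. Compound 1 differs from compound 2 in more than one place, so the role of the linker also stays unresolved.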